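This account rests on a few compounds, and the source may have more. Where it says the series, first, only, none or still open, it means among the compounds named here.

Measured compounds in a toxicity assay on NIH3T3 cells (Mus musculus) for cytotoxicity, read by resazurin assay; on this read-out lower numbers stand for an effect already at smaller amounts and higher numbers for an effect only at larger amounts of compound:
compound 1, `Clc1ccc(Cn2cncc2CNc2cccc(-c3ccccc3)c2)cc1`, with 10000 nM;
compound 2, `COC(=O)c1ccc(NCc2cncn2Cc2ccc(C(C)(C)C)cc2)cc1-c1ccccc1`, with "not determined" (no result reported);
compound 3, `O=C(OC1CCCCC1)c1ccc(NCc2cncn2Cc2ccc(-c3ccccc3)cc2)cc1-c1ccccc1`, with > 10000 nM.

For compound 3 the entry is a limit of this assay rather than a number, so the limit of > 10000 nM in this assay, at which 1 of the 3 values shown sits, marks where it stands among the three values shown. Compound 2 has no result in this assay. Compound 4, `CCCC(=O)c1ccc(NCc2cncn2Cc2ccc(-c3ccccc3)cc2)cc1-c1ccccc1`, has not yet been measured there. It differs from compound 3 in one place: propyl in place of cyclohexyloxy on a carbonyl carbon. Among the measured compounds shown here, no measured step of this kind is available, so the expectation rests on the position of compound 3 alone. The step from compound 3 to compound 4 is expected to be about a number no higher from compound 3 to compound 4 (the limit leaves the size open), that is, no change beyond the usual scatter. Compound 4 is thus estimated at 10000 nM in this assay, within a range from 3000 nM to 30000 nM.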

Compound 4, half-maximal effective concentration: > 10000 nM
Compound 4 was reported as a limit; the forecaster's own chance of this, stated with the estimate: 50%; the middle value sits exactly at the limit.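

Compound 3 and compound 4 are both reported only as limits in this assay, and no step between them can be read: the limit of > 10000 nM in this assay, at which 2 of the 4 values shown sit.

The compounds shown leave open whether propyl in place of cyclohexyloxy on the carbonyl carbon changes the result at all.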